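The source may report more compounds than this note shows. Statements on the series, on what has been measured and on what is new or still open speak of the compounds shown alone.

Measured so far:
- compound 1, `C[C@@H](O)[C@H](NC(=O)CN(c1ncnc2c1ncn2C1CCCCO1)C1CC1)C(=O)OCc1ccccc1`: 28.4%
- compound 2, `NC(=O)C[C@H](NC(=O)CN(c1ncnc2c1ncn2C1CCCCO1)C1CC1)C(=O)OCc1ccccc1`: 30.5%
- compound 3, `C[C@H](NC(=O)CN(c1ncnc2c1ncn2C1CCCCO1)C1CC1)C(=O)OCc1ccccc1`: 53%

Compound 3 holds the highest number of the three in a functional assay on the whole organism (Tail, strain ICR) with Mus musculus as the target, in the tail flick test, with a stated time of 60 min, at a dose of 25 umol/kg by the oral route; a higher number here means a stronger effect of the compound at the dose given, a lower number a weaker effect; the nearest is compound 2, and the furthest is compound 1, both beyond the scatter. Compound 4, `N=C(N)NCCC[C@H](NC(=O)CN(c1ncnc2c1ncn2C1CCCCO1)C1CC1)C(=O)OCc1ccccc1`, is the next step and differs from compound 3 by a group of 6 heavy atoms (3 carbon, 3 nitrogen; no ring) in place of a hydrogen atom, on a saturated chain carbon, two bonds along the chain from an amide-type nitrogen and a carbonyl carbon.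

Among the compounds with values here, two measured steps bear on this: a number 24.6 percentage points higher from compound 1 to compound 3 (beyond the scatter) and a number 22.5 percentage points higher from compound 2 to compound 3 (beyond the scatter). Each arrives at compound 3 by removing a group from the same chain carbon, and each gains modestly in this assay. Compound 4 goes the opposite way, putting a group of 6 heavy atoms back onto that carbon, so the expected step is a modest fall, beyond the scatter, of about the same size as those two. Within the data shown here, no measured step tells what a group of 3 carbon and 3 nitrogen atoms with 3 hydrogen-bond donors does here, so the range is kept wide.

Compound 4 is therefore estimated at 30%, within 12% to 50%, an expected step of a number 23 percentage points lower from compound 3 to compound 4 (beyond the scatter).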

Compound 4, a percentage reported as activity, at one dose (the size of the read-out at that dose, not a potency): 52.4%
The estimate for compound 4 lay 22.4 percentage points below the measured number; the whole stated range lies below it.
By their numbers in this assay, from the lowest: compounds 1 and 2 (each within the scatter of the next); then compounds 4 and 3 (each within the scatter of the next).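

In this assay, the group of 6 heavy atoms (3 carbon, 3 nitrogen; no ring) on a saturated chain carbon, two bonds along the chain from an amide-type nitrogen and a carbonyl carbon, costs nothing against a hydrogen atom: a number 0.6 percentage points lower from compound 3 to compound 4 (within the scatter). A group on this chain is therefore not in itself linked to the lower read-out, as a number 21.9 percentage points higher from compound 2 to compound 4 (beyond the scatter) and a number 24 percentage points higher from compound 1 to compound 4 (beyond the scatter); among these compounds, the outcome depends on which group is present. Nothing measured here accounts for this difference between the groups.

The compounds shown leave open whether an amine or a carboxylic acid at the end of this chain would read like compound 4. On these data alone, all four share everything outside this one substituent, so changes elsewhere remain untested here.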